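Pyrazinyl Analogue Expected from Three Measured Biaryl Compounds

The source may report more compounds than this note shows. Statements on the series, on what has been measured and on what is new or still open speak of the compounds shown alone.

Measured compounds:
compound 1 `c1ccc(-c2cnco2)c(NCC2=NCCN2)c1` — 17.4 nM
compound 2 `Cc1ccsc1-c1ccccc1NCC1=NCCN1` — 0.851 nM
compound 3 `Cc1ccc(-c2ccccc2NCC2=NCCN2)o1` — 2.69 nM

In a functional assay for activation of Alpha-1A adrenergic receptor (Homo sapiens), read by calcium flux (a lower number here means that less compound is needed, a higher number that more compound is needed for the effect), compound 3 stands second highest of the three numbers: it is separated from its nearest neighbour by a 3.2-fold higher number from compound 2 to compound 3 (0.50 log units; beyond the scatter) and from the furthest by a 6.5-fold lower number from compound 1 to compound 3 (0.81 log units; beyond the scatter). Compound 4 `c1ccc(-c2cnccn2)c(NCC2=NCCN2)c1` differs from compound 3 by pyrazin-2-yl in place of 5-methylfuran-2-yl on an aromatic carbon. Among the compounds with values here, the steps that bear on this are a 6.5-fold lower number from compound 1 to compound 3 (0.81 log units; beyond the scatter) and a 20-fold lower number from compound 1 to compound 2 (1.31 log units; beyond the scatter), both of which moved away from the 1,3-oxazol-5-yl of compound 1; the entering pyrazin-2-yl resembles that group more than the 5-methylfuran-2-yl it replaces. A return toward the number of compound 1 is therefore expected, as a 6.7-fold higher number from compound 3 to compound 4 (0.83 log units; beyond the scatter). Compound 4 is estimated at 18 nM, within 5 nM to 70 nM.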

Compound 4, half-maximal effective concentration: 4.57 nM
Compound 4: middle estimate off by 3.9-fold (0.60 log units), on the high side; the measured number lies below the stated range.
By their numbers in this assay, from the lowest: compound 2; then compounds 3 and 4 (each within the scatter of the next); then compound 1.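

At this aromatic carbon, pyrazin-2-yl in place of 5-methylfuran-2-yl gives (a 1.7-fold higher number from compound 3 to compound 4 (0.23 log units; within the scatter)) in this assay, so a six-membered aromatic ring serves here as well as the five-membered one. The pyrazin-2-yl nonetheless stays apart from the 1,3-oxazol-5-yl (a 3.8-fold lower number from compound 1 to compound 4 (0.58 log units; beyond the scatter)) and from the 3-methylthiophen-2-yl (a 5.4-fold higher number from compound 2 to compound 4 (0.73 log units; beyond the scatter)), so its likeness to the former did not carry the number with it. Nothing measured here accounts for these steps.

As far as these compounds go, whether a pyridin-2-yl or a plain phenyl at this place would sit with compound 4 or with compound 2 remains open. So does the effect of a methyl on the pyrazin-2-yl.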